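Bromine for Chlorine on an Azepane-Bearing Pyridine Core

A few compounds are considered here, and "the series" means these few. Any claim that something is new, unique, unknown or untested is made for them only; others in the source may bear on it.

Compound 2 `Clc1cncc(N2CCCNCCC2)c1` is the best of the three compounds measured in an assay on HEK293 cells with Neuronal acetylcholine receptor; alpha4/beta2 (Homo sapiens) as the target, read by FLIPR and calcium flux; on this read-out higher numbers stand for larger maximal responses and lower numbers for smaller maximal responses: in this assay compound 2 gives 103%. Its nearest neighbour is compound 1 `c1cncc(N2CCCNCCC2)c1`, which in this assay gives 78%, and the furthest is compound 3 `C=COc1cncc(N2CCNCC2)c1`, which in this assay gives 18%. Among the measured compounds shown here, the only single-point step among the measured compounds is the one from compound 1 to compound 2, where a chloro in place of hydrogen on an aromatic carbon gave a number 25 percentage points higher from compound 1 to compound 2 (beyond the scatter).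

Compound 4 `Brc1cncc(N2CCCNCCC2)c1` differs from compound 2 in one place: bromo in place of chloro on an aromatic carbon. For the measured compounds named here, no measured step exchanges one halogen for another, so the step from compound 1 to compound 2 is the only one with any bearing; it shows that a halogen at this aromatic carbon is well tolerated, but it does not tell how bromo compares with chloro. The reasonable expectation is therefore a step from compound 2 to compound 4 of a number 3 percentage points lower from compound 2 to compound 4 (within the scatter), that is, none beyond the scatter.

On that basis the maximal response of compound 4 in this assay is estimated at 100%, with a range from 80% to 120%.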

Compound 4, largest response reached (reported as efficacy), in percent of the reference or control that the assay uses: 73%
Compound 4: middle estimate off by 27 percentage points, on the high side, outside the stated range (below it).
By their numbers in this assay, from the lowest: compound 3; then compounds 4 and 1 (each within the scatter of the next); then compound 2.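

Among the compounds shown here, at this aromatic carbon, two atoms from the ring nitrogen, the choice of halogen matters in this assay: bromo in place of chloro gives a number 30 percentage points lower from compound 2 to compound 4 (beyond the scatter) and thus separates two groups that the earlier compounds could not tell apart. Bromo in place of hydrogen gives a number 5 percentage points lower from compound 1 to compound 4 (within the scatter) and so, of the two halogens shown, only chloro stands clear of the unsubstituted compound, which ties the earlier step of a number 25 percentage points higher from compound 1 to compound 2 (beyond the scatter) to chloro itself and not to halogens in general. Nothing among the available data accounts for the difference between chloro and bromo at this position.

The compounds shown leave open how fluoro, iodo, methyl or nitrile at this aromatic carbon would compare with chloro in this assay and whether chloro is a single favourable case or part of a wider trend. They also leave open whether the exchange of chloro for bromo would have a similar outcome on the core of compound 3, which carries a vinyloxy group in place of the halogen.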